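This account rests on a few compounds, and the source may have more. Where it says the series, first, only, none or still open, it means among the compounds named here.

Measured so far in an assay on CHO cells for displacement of a labelled ligand from Glucagon receptor (Homo sapiens), read by scintillation counting, with a stated time of 60 min; on this read-out higher numbers stand for weaker inhibition and lower numbers for stronger inhibition:
compound 1, `CC(C)(C)CC[C@H](c1ccc(C(=O)NCc2nn[nH]n2)cc1)N1C(=O)C(c2cncc(Cl)c2)=N[C@]12CC[C@@H](C(C)(C)C)CC2`: 38 nM
compound 2, `C[C@H](c1ccc(C(=O)NCCC(=O)O)cc1)N1C(=O)C(c2ccccc2F)=N[C@]12CC[C@@H](C(C)(C)C)CC2`: 1100 nM
compound 3, `CC(C)(C)CC[C@H](c1ccc(C(=O)NCc2nn[nH]n2)cc1)N1C(=O)C(c2cccc(C(F)(F)F)c2)=N[C@]12CC[C@@H](C(C)(C)C)CC2`: 13 nM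

Compound 2 stands highest of the three numbers in this assay: compound 1 sits a step below it and compound 3 further below, both gaps beyond the scatter. Compound 4, `C[C@H](c1ccc(C(=O)NCCC(=O)O)cc1)N1C(=O)C(c2ccc(F)cc2)=N[C@]12CC[C@@H](C(C)(C)C)CC2`, is not yet measured. It differs from compound 2 by 4-fluorophenyl in place of 2-fluorophenyl on a carbon with a double bond to nitrogen.

Among the compounds with values here, the only measured step that exchanges the group on the carbon with a double bond to nitrogen is a 2.9-fold lower number from compound 1 to compound 3 (0.47 log units; beyond the scatter), a modest step. That exchange replaces 5-chloropyridin-3-yl with 3-(trifluoromethyl)phenyl, which is a different pair of groups, and compound 1 and compound 3 carry a different side chain and a different amide than compound 2 does. Within the data shown here, no measured pair exchanges one fluorophenyl for another, so nothing bears directly on the step from compound 2 to compound 4. Among the measured compounds shown here, the one aryl exchange seen at this position gave a modest step, and the present change is an exchange of the same kind but with the same atoms in both groups. The expectation for compound 4 in this assay is therefore a step of no change at the digits printed from compound 2 to compound 4 (within the scatter), not beyond the scatter, with no direction preferred. Compound 4 is estimated at 1100 nM, with a range from 400 nM to 3000 nM.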

Compound 4, half-maximal inhibitory concentration: 85 nM
Beside the measured number, compound 4's estimate is 13-fold (1.11 log units) above it, outside the stated range (below it).
By their numbers in this assay, from the lowest: compound 3; then compound 1; then compound 4; then compound 2.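

In this assay, exchanging 2-fluorophenyl for 4-fluorophenyl gives a 13-fold lower number from compound 2 to compound 4 (1.11 log units; beyond the scatter), so the read-out at this position depends on more than which atoms the group contains: the two groups have the same atoms and the same counts of heavy atoms, donors and acceptors, and differ only in how they are joined. Within the data shown here, the only earlier exchange on the carbon with a double bond to nitrogen, a 2.9-fold lower number from compound 1 to compound 3 (0.47 log units; beyond the scatter), was modest, but it involved a different pair of groups on compounds with a different side chain and amide, so it gave no sign that an exchange between two fluorophenyl groups could produce a large step. Nothing available accounts for the size of this step.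

From the compounds shown here alone, without unsubstituted phenyl or 3-fluorophenyl on the same background, it remains open whether 2-fluorophenyl raises the number, 4-fluorophenyl lowers it, or both contribute. Going by these compounds, it is also open whether the same exchange gives a step of similar size on the background of compound 1 and compound 3, which carries the longer chain in place of the methyl group of compound 2 and compound 4.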